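Chloro for Hydrogen: From Compound 2 to Compound 3

The source may hold more compounds than are shown below. What is called first, only, known or untested is meant among the compounds shown, and "the series" means these compounds.

Compound 2 `CCOC(=O)Cc1n[nH]c(NC(=O)c2ccccc2)n1` stands lowest of the two numbers measured in a functional assay on the whole organism (strain albino) for inhibition, with Rattus norvegicus as the target, read by paw edema, with stated times of 30 min and 2 h, at a dose of 5 mg/kg by the oral route (on this read-out lower numbers stand for less inhibition and higher numbers for more inhibition at the one dose given (going by the name of the read-out)), where compound 2 gives 36.2%; compound 1 `CCOC(=O)Cc1nc(N)n(C(=O)c2ccc([N+](=O)[O-])cc2)n1` gives 46.3% in this assay, a number beyond the scatter above it. Compound 3 `CCOC(=O)Cc1n[nH]c(NC(=O)c2ccc(Cl)cc2)n1` differs from compound 2 in one place: chloro in place of hydrogen on an aromatic carbon. For the measured compounds named here, no step between measured compounds covers this change, so only a small rise, within the scatter, is expected, the step of a number 3.8 percentage points higher from compound 2 to compound 3 (within the scatter). Compound 3 is therefore estimated at 40%, with a range from 30% to 52%.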

Compound 3, a percentage reported as inhibition, in the whole organism at one dose (the size of the read-out at that dose, not a potency): 39.1%
For compound 3 the middle estimate is 0.9 percentage points above the measured one; the measured number falls inside the stated range.
By their numbers in this assay, from the lowest: compounds 2, 3 and 1 (each within the scatter of the next, the first and the last beyond it).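

In this assay, chloro in place of hydrogen on an aromatic carbon, para to a large group, gives a number 2.9 percentage points higher from compound 2 to compound 3 (within the scatter) and so stays within the usual scatter of repeated measurements. For the compounds shown here, this is the first reading of a single change at this position, as compound 1 and compound 2 differ in more than one place. At this one dose, phenyl to 4-chlorophenyl is therefore a change the read-out does not separate.

As far as these compounds go, whether a methoxy group, an amine or a carboxylic acid at this same place would give a step beyond the scatter stays open, as does the effect of chloro elsewhere on the six-membered aromatic ring. No measurement shown here bears on the size of this step.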